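Taking the methoxy off compound 2

This account rests on a few compounds, and the source may have more. Where it says the series, first, only, none or still open, it means among the compounds named here.

Two compounds of the series have readings so far in a functional assay on PC-3 cells (Homo sapiens) for cytotoxicity, read by WST assay, with a stated time of 48 h; a lower number here means a stronger inhibitor, a higher number a weaker inhibitor. Compound 1 `N#C/C(=C\c1cn(Cc2ccc(Cl)cc2)c2ccc(Br)cc12)C(=O)c1c[nH]c2ccccc12` gives 36500 nM. Compound 2 `COc1ccc2c(C(=O)/C(C#N)=C/c3cn(Cc4ccc(Cl)cc4)c4ccccc34)c[nH]c2c1` is reported only as > 50000 nM, which is a limit of the assay and not a number. Compound 2 therefore stands at the limit of > 50000 nM in this assay, at which 1 of the 2 values shown sits. The two compounds differ in more than one place, so no single change can be read from them.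

The next compound is compound 3 `N#C/C(=C\c1cn(Cc2ccc(Cl)cc2)c2ccccc12)C(=O)c1c[nH]c2ccccc12`, where the change from compound 2 is hydrogen in place of methoxy on an aromatic carbon, turning 6-methoxy-1H-indol-3-yl into 1H-indol-3-yl. Going by the values given here, no measured step covers this change. Among the compounds with values here, the only numeric reading is compound 1 at 36500 nM, so a small move towards lower numbers in this assay is expected, possibly none beyond the scatter. The expected size is an at least 1.4-fold lower number from compound 2 to compound 3 (0.15 log units; that floor lies within the scatter), and a reading at the limit would not be a surprise. For compound 3 the estimated value is 35000 nM, with an expected range of 12000 nM to 70000 nM.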

Compound 3, half-maximal inhibitory concentration: > 50000 nM
Compound 3 gave a limit, no number (the forecaster's own chance of this, stated with the estimate: 35%); middle value at least 1.4-fold (0.15 log units) from the limit.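

In this assay compound 3 gives > 50000 nM which is a limit of the assay and not a number, and the reading of compound 2 is a limit too, so the step for hydrogen in place of methoxy on an aromatic carbon cannot be read: the limit of > 50000 nM in this assay, at which 2 of the 3 values shown sit.

Neither the methoxy on compound 2 nor the hydrogen on compound 3 gives a reading inside the range of the assay.

Going by these compounds alone, compound 3 does provide the first comparison in one place with a number on one side: hydrogen in place of bromo on an aromatic carbon gives an at least 1.3-fold higher number from compound 1 to compound 3 (0.13 log units; that floor lies within the scatter) and, with that floor within the scatter, the compounds do not yet show that the bromo matters.

Going by these compounds, the true size of the bromo step remains unknown beyond its floor, and any difference between 6-methoxy-1H-indol-3-yl and 1H-indol-3-yl remains hidden behind the two limits.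

Also open, on these data alone, is how an amine or a carboxylic acid on the aromatic carbon that carries the bromo in compound 1 would read in this assay on this shared core.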